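A few compounds are considered here, and "the series" means these few. Any claim that something is new, unique, unknown or untested is made for them only; others in the source may bear on it.

Measured compounds in a functional assay on PC-3 cells (Homo sapiens) for cytotoxicity, read by MTT assay, with a stated time of 24 h; on this read-out higher numbers stand for weaker inhibition and lower numbers for stronger inhibition:

- compound 1 `O=C1/C(=C/c2ccccc2F)CN(C(=S)SCc2cn(Cc3ccccc3Cl)nn2)C/C1=C\c1ccccc1F`; in this assay compound 1 gives > 80000 nM, which is a limit of the assay and not a number.
- compound 2 `O=C1/C(=C/c2ccccc2F)CN(C(=S)SCc2cn(Cc3ccc(F)cc3)nn2)C/C1=C\c1ccccc1F`; in this assay compound 2 gives > 80000 nM, again a limit of the assay.
- compound 3 `O=C1/C(=C/c2ccccc2F)CN(Cc2cn(Cc3ccccc3Cl)nn2)C/C1=C\c1ccccc1F`; in this assay compound 3 gives 7100 nM.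

Compound 1 and compound 2 share one core; compound 3 is built on another, and the difference between the two cores is not broken down here. Within the first pair the change is 4-fluorophenyl in place of 2-chlorophenyl on a saturated chain carbon bound to an aromatic nitrogen. The step it makes is a step that the two limits leave unreadable from compound 1 to compound 2. Both values sit at the limit of > 80000 nM in this assay, at which 2 of the 3 values shown sit, so this pair tells nothing about the size or direction of the change. Compound 3 is the only compound of the three for which a number rather than a limit is shown.

Compound 4 `O=C1/C(=C/c2ccccc2F)CN(Cc2cn(Cc3ccc(F)cc3)nn2)C/C1=C\c1ccccc1F` carries the same change on the core of compound 3: 4-fluorophenyl in place of 2-chlorophenyl on a saturated chain carbon bound to an aromatic nitrogen. Within the data shown here, the one measured instance of this change gives no readable size, so the expectation for compound 4 rests on compound 3 alone, whose value in this assay is 7100 nM, with the change taken as roughly neutral. The expected step is a 1.3-fold higher number from compound 3 to compound 4 (0.10 log units; within the scatter), which is meant to lie within the usual scatter. Compound 4 is therefore estimated at 9000 nM, with a range from 3000 nM to 40000 nM, the range being kept wide since the second core has no measured companion.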

Compound 4, half-maximal inhibitory concentration: 19400 nM
Compound 4: the middle estimate sits 2.2-fold (0.33 log units) below what was measured, and the stated range covers the measured number.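

In this assay, the change from 2-chlorobenzyl to 4-fluorobenzyl, on a saturated chain carbon bound to an aromatic nitrogen, reads as a 2.7-fold higher number from compound 3 to compound 4 (0.44 log units; beyond the scatter), a modest step towards weaker inhibition that lies beyond the usual scatter. The same change on the core of compound 1 cannot be read, because compound 1 and compound 2 both stand at a limit of the assay and not at a number: the limit of > 80000 nM in this assay, at which 2 of the 4 values shown sit. Its direction and size are therefore known on one core only, so the data neither support nor contradict carrying it from one core to the other, and a single readable step sets no pattern for the series.

The step replaces 2-chlorobenzyl with 4-fluorobenzyl in a single move, so the compounds shown do not separate the part played by the halogen from the part played by its place on the ring, and they give no reference point in which the benzyl ring is unsubstituted. Also open, as far as these compounds go, is whether a methoxy group, an amine or a carboxylic acid on that benzyl ring, or a longer chain in place of its saturated carbon, would give a readable number on the core of compound 1 or shift the value on the core of compound 3.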